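The compounds below may be only part of what the source reports. "The series", "measured", "known", "first", "only" and "open" are said of these compounds alone.

Measured compounds:
Compound 1, `CCCCCCC[C@H]1C[C@H](Br)CCN1S(=O)(=O)c1ccc(C)cc1`: in a functional assay on A2780 cells (Homo sapiens) for antiproliferative activity, read by sulforhodamine B assay, with a stated time of 48 h (a higher number here means a weaker inhibitor of growth, a lower number a stronger inhibitor of growth), compound 1 gives > 100000 nM, a limit of the assay rather than a number.
Compound 2, `Cc1ccc(S(=O)(=O)N2CC[C@@H](Br)C[C@@H]2C2CCCCC2)cc1`: compound 2 gives > 100000 nM, again a limit of the assay.
Compound 3, `CCCCCCCC1C=C(Cl)CCN1S(=O)(=O)c1ccc(C)cc1`: compound 3 gives 92000 nM.

Compounds 1 and 2 are related by a single change, (cyclohexyl in place of heptyl on a saturated ring carbon). The step that the two limits leave unreadable from compound 1 to compound 2 cannot be read because of the limit of > 100000 nM in this assay, at which 2 of the 3 values shown sit. Among the measured compounds shown here, compound 3 is the only compound here with a number in this assay; the difference between its core and the core of compound 1 is not broken down here.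

Compound 4, `Cc1ccc(S(=O)(=O)N2CCC(Cl)=CC2C2CCCCC2)cc1`, has not been measured. It differs from compound 3 by cyclohexyl in place of heptyl on a saturated ring carbon. This is the same kind of change as from compound 1 to compound 2, but the surroundings differ: in compound 3 the saturated ring carbon lies two ring bonds from the ring atom that bears a chloro group, in compound 1 from the ring atom that bears a bromo group. With the earlier step unreadable, the expectation rests on compound 3 alone, which gives 92000 nM in this assay. The step expected is a 1.1-fold higher number from compound 3 to compound 4 (0.04 log units; within the scatter). Compound 4 is estimated at 100000 nM, between 45000 nM and 250000 nM.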

Compound 4, concentration for 50% growth inhibition: 39000 nM
Estimate against measurement, compound 4: 2.6-fold (0.41 log units) above; measured number below the stated range.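

On the core that carries the chloro group, in this assay, cyclohexyl in place of heptyl on a saturated ring carbon gives a 2.4-fold lower number from compound 3 to compound 4 (0.37 log units; beyond the scatter), a modest step that lies beyond the scatter. The same change on the core of compound 1 offers no size for comparison, and the step from compound 1 to compound 2 cannot be read because both values are limits of the assay: the limit of > 100000 nM in this assay, at which 2 of the 4 values shown sit. The result therefore shows the effect of this change on one core only, and it does not show that the change carries from one core to the other with the same direction or size.

From the compounds shown here alone, it remains open whether an amine, a carboxylic acid or a longer chain in place of heptyl on that saturated ring carbon would move the number in this assay. Also open, going by these compounds, is how much of the difference between the core of compound 1 and the core of compound 3 comes from the bromo and chloro groups.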